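Ethoxycarbonyl in Place of Methyl: Expected Tolerance of Compound 4

The source may report more compounds than this note shows. Statements on the series, on what has been measured and on what is new or still open speak of the compounds shown alone.

Compound 1, `CCNC(=O)NC1=CS(=O)(=O)O[C@@]12[C@@H](CO[Si](C)(C)C(C)(C)C)O[C@@H](n1cc(C)c(=O)n(C)c1=O)[C@@H]2O[Si](C)(C)C(C)(C)C`, is one of three measured compounds. In a functional assay on HEL cells (Homo sapiens) for cytotoxicity, read by microscopy (a lower number here means that less compound is tolerated, a higher number that more compound is tolerated), compound 1 gives >= 3200 nM, which is a limit of the assay and not a number. Compound 2, `Cc1cn([C@@H]2O[C@H](CO[Si](C)(C)C(C)(C)C)[C@@]3(OS(=O)(=O)C=C3NCCC(=O)OCc3ccccc3)[C@H]2O[Si](C)(C)C(C)(C)C)c(=O)n(C)c1=O`, likewise gives >= 400000 nM, again a limit. Compound 3, `Cc1cn([C@@H]2O[C@H](CO[Si](C)(C)C(C)(C)C)[C@@]3(OS(=O)(=O)C=C3NCCC(=O)O)[C@H]2O[Si](C)(C)C(C)(C)C)c(=O)n(C)c1=O`, gives 80000 nM. Among the measured steps, a step that the two limits leave unreadable from compound 1 to compound 2 and a step that the limit leaves unreadable from compound 1 to compound 3, whereas an at least 5.0-fold lower number from compound 2 to compound 3 (0.69 log units; beyond the scatter). Compound 1 therefore stands at a limit, as the limit of >= 3200 nM in this assay, at which 1 of the 3 values shown sits, records, and its place relative to the other two cannot be read.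

Compound 4, `CCOC(=O)CNC(=O)NC1=CS(=O)(=O)O[C@@]12[C@@H](CO[Si](C)(C)C(C)(C)C)O[C@@H](n1cc(C)c(=O)n(C)c1=O)[C@@H]2O[Si](C)(C)C(C)(C)C`, differs from compound 1 by ethoxycarbonyl in place of methyl on a saturated chain carbon bound to an amide-type nitrogen. Within the data shown here, no measured step touches this position: the readable step swaps hydrogen for benzyl on an oxygen next to a carbonyl group, and the two steps from compound 1 are hidden by its limit. The change in compound 4 is thus without a measured precedent. Since compound 1 is tolerated up to its limit, the expected step is a step that the limit leaves unreadable from compound 1 to compound 4, with no shift beyond the scatter expected. Compound 4 is estimated to give 8000 nM, with a range from 2000 nM to 100000 nM, and the result is expected to appear again as a limit.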

Compound 4, minimum cytotoxic concentration: 16000 nM
For compound 4 the middle estimate is 2.0-fold (0.30 log units) below the measured one; low and high end bracket the measured number.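

Compound 4 gives a readable number for a group on a saturated chain carbon bound to an amide-type nitrogen, so this position can now be set against the other compounds in this assay. The ((ethoxycarbonyl)methyl)carbamoyl group goes with less tolerated compound than either chain on the amine nitrogen, with a 5.0-fold lower number from compound 3 to compound 4 (0.70 log units; beyond the scatter) and an at least 25-fold lower number from compound 2 to compound 4 (1.39 log units; beyond the scatter). Compound 1 stands at a limit, so the step that puts ethoxycarbonyl in place of methyl cannot be read: the limit of >= 3200 nM in this assay, at which 1 of the 4 values shown sits.

The compounds shown therefore leave open how much of the number of compound 4 belongs to ethoxycarbonyl itself and how it compares with the plain ethylcarbamoyl group. They also leave open whether a carboxylic acid or a primary amide in place of ethoxycarbonyl on that saturated chain carbon, or a longer chain carrying the same ester, would move the number in this assay up, down or not at all.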